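Swapping the amine in three cytotoxicity compounds

A few compounds are considered here, and "the series" means these few. Any claim that something is new, unique, unknown or untested is made for them only; others in the source may bear on it.

Compound 1 `CC1CCN(Cc2ccc3nc(NC(=O)N/N=C/c4cn(Cc5ccc(Cl)cc5Cl)c5ccccc45)sc3c2)CC1`: 3640 nM
Compound 2 `CC1CCN(Cc2ccc3nc(NC(=O)N/N=C4\C(=O)Nc5ccc(F)cc54)sc3c2)CC1`: 3010 nM
Compound 3 `CCN(CC)Cc1ccc2nc(NC(=O)N/N=C/c3cn(Cc4ccc(Cl)cc4Cl)c4ccccc34)sc2c1`: 1900 nM

Of the compounds shown here, three have been measured in a functional assay on A549 cells (Homo sapiens) for cytotoxicity, read by MTT assay, with a stated time of 72 h; a higher number here means a weaker inhibitor, a lower number a stronger inhibitor. Compound 1 gives 3640 nM, compound 2 gives 3010 nM and compound 3 gives 1900 nM. The difference between the cores of compound 1 and compound 2 is not broken down here. Compound 3 differs from compound 1 by diethylamino in place of 4-methylpiperidin-1-yl on a saturated chain carbon bound to an aromatic carbon, and this change made a step of a 1.9-fold lower number from compound 1 to compound 3 (0.28 log units; within the scatter).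

Compound 4 `CCN(CC)Cc1ccc2nc(NC(=O)N/N=C3\C(=O)Nc4ccc(F)cc43)sc2c1` has not yet been measured in this assay. It differs from compound 2 by diethylamino in place of 4-methylpiperidin-1-yl on a saturated chain carbon bound to an aromatic carbon, the same change seen between compound 1 and compound 3, at a place described in the same words. Since that earlier change produced a 1.9-fold lower number from compound 1 to compound 3 (0.28 log units; within the scatter), compound 4 is expected to sit near compound 2, with an estimated step of a 1.7-fold lower number from compound 2 to compound 4 (0.22 log units; within the scatter). For compound 4 the estimate in this assay is 1800 nM, expected to lie between 700 nM and 4500 nM.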

Compound 4, half-maximal inhibitory concentration: 2010 nM
Compound 4: middle estimate off by 1.1-fold (0.05 log units), on the low side; the range from low to high includes it.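

In this assay, diethylamino in place of 4-methylpiperidin-1-yl on the second core gives a 1.5-fold lower number from compound 2 to compound 4 (0.18 log units; within the scatter). Set beside the earlier case, the change reads alike on both cores: the same change on two cores in this assay, a 1.9-fold lower number (0.28 log units; within the scatter) from compound 1 to compound 3 and a 1.5-fold lower number (0.18 log units; within the scatter) from compound 2 to compound 4, 1.3-fold (0.11 log units) apart, within the scatter of two such steps. This shows that the swap left the number within the scatter on each of the two cores, so the two amines cannot be told apart in this assay, and it does not show that the change has a real effect of its own or that the agreement would hold on any further core in the series.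

The compounds shown leave open whether another amine on the same saturated chain carbon, such as morpholin-4-yl or piperazin-1-yl, would move the number beyond the scatter. They also leave open what a group of a different kind at that place, such as a carboxylic acid, would do on either core.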